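The compounds below may be only part of what the source reports. "The series", "measured", "known", "first", "only" and "open" are said of these compounds alone.

Measured so far:
- compound 1 `O=C(CN1CCCC1)Nc1ccc(-c2nc3cc(C(F)(F)F)ccc3[nH]2)cc1`: 29000 nM
- compound 2 `CCN(CC)CC(=O)Nc1ccc(-c2nc3cc(C(F)(F)F)ccc3[nH]2)cc1`: 23000 nM

Both compounds were tested in an ADME assay on BHK cells (Mesocricetus auratus) for cytotoxicity, read by MTT assay, with a stated time of 96 h; a lower number here means that less compound is tolerated, a higher number that more compound is tolerated. Compound 2 gives 23000 nM, the lowest of the two numbers; its nearest neighbour is compound 1, and the step of a 1.3-fold lower number from compound 1 to compound 2 (0.10 log units; within the scatter) lies within the scatter, so the two cannot be told apart on these numbers.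

Compound 3 `O=[N+]([O-])c1ccc(-c2nc3cc(C(F)(F)F)ccc3[nH]2)cc1` has not yet been measured. It differs from compound 2 in one place: nitro in place of (((diethylamino)methyl)carbonyl)amino on an aromatic carbon. Going by the values given here, this is a change at a different site from the one varied between compound 1 and compound 2, where only the amine at the end of the chain was exchanged. Among the compounds with values here, no measured step bears directly on removing the whole amide chain, so the only measured step gives no guide to the size or direction of the change, and the expectation rests on the fact that the shared core is kept.

On that basis compound 3 is expected to give about 30000 nM in this assay, within a wide range from 8000 nM to 110000 nM, which means an expected step of a 1.3-fold higher number from compound 2 to compound 3 (0.12 log units; within the scatter), not clearly beyond the scatter in either direction.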

Compound 3, half-maximal cytotoxic concentration: 18000 nM
Estimate against measurement, compound 3: 1.7-fold (0.22 log units) above, and the stated range covers the measured number.
By their numbers in this assay, from the lowest: compounds 3, 2 and 1 (each within the scatter of the next).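

In this assay, nitro in place of the (((diethylamino)methyl)carbonyl)amino chain on the aromatic carbon gives a small step (a 1.3-fold lower number from compound 2 to compound 3 (0.11 log units; within the scatter)), and nitro in place of the (((pyrrolidin-1-yl)methyl)carbonyl)amino chain gives another (a 1.6-fold lower number from compound 1 to compound 3 (0.21 log units; within the scatter)). Compounds 1 and 2 differed only in the amine at the end of the chain, whereas here the whole chain goes, taking the count from 9 heavy atoms to 3 and the hydrogen-bond donors from 1 to 0, and the number still does not move beyond the scatter in either step. Nothing measured on these compounds explains why the exchange leaves the reading within the scatter.

Going by these compounds, it remains open whether any group on this aromatic carbon can shift the number beyond the scatter, for example a plain amine, a carboxylic acid or a longer chain. The trifluoromethyl group also stays the same in all three compounds, so what a hydrogen or a chlorine in its place would do is equally unanswered.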